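Swapping Pyrimidin-2-yl for Quinolin-2-yl on an Amine Nitrogen

The compounds below may be only part of what the source reports. "The series", "measured", "known", "first", "only" and "open" are said of these compounds alone.

Of the compounds shown here, two have been measured so far. Compound 1 `CN(C(=O)C[C@@H](N)CCCN=C(N)N)C1CN=C(NC(N)=O)NC1=O` carries a carbamoyl group on an amine nitrogen of the shared core; in a functional assay for inhibition, with Oryctolagus cuniculus as the target (a higher number here means a weaker inhibitor, a lower number a stronger inhibitor), compound 1 gives 170 nM. Compound 2 `CN(C(=O)C[C@@H](N)CCCN=C(N)N)C1CN=C(Nc2ncccn2)NC1=O` carries pyrimidin-2-yl at that position instead; in this assay compound 2 gives 100 nM. The step of a 1.7-fold lower number from compound 1 to compound 2 (0.23 log units; within the scatter) lies within the scatter, so the two numbers cannot be told apart. Among the measured compounds shown here, compound 2 has the lower of the two numbers, but its only neighbour, compound 1, sits within the scatter of it.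

Compound 3 `CN(C(=O)C[C@@H](N)CCCN=C(N)N)C1CN=C(Nc2ccc3ccccc3n2)NC1=O` differs from compound 2 in one place: quinolin-2-yl in place of pyrimidin-2-yl on an amine nitrogen. For the measured compounds named here, no measured step involves a quinolin-2-yl group, so the only step that bears on this change is the earlier exchange at the same amine nitrogen, a 1.7-fold lower number from compound 1 to compound 2 (0.23 log units; within the scatter), which stayed within the scatter. One small step gives little ground for expecting a large change in this assay in either direction. Compound 3 is therefore expected to give about 100 nM in this assay, with a range from 40 nM to 300 nM. This estimate means a step of no change at the digits printed from compound 2 to compound 3 (within the scatter), expected to stay within the scatter.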

Compound 3, half-maximal inhibitory concentration: 100 nM
Compound 3: middle estimate and measured number agree at the digits printed; measured number inside the range.
By their numbers in this assay, from the lowest: compounds 2, 3 and 1 (each within the scatter of the next).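

At this amine nitrogen, quinolin-2-yl brings a second aromatic ring and takes the group from 6 heavy atoms to 10 heavy atoms and from 2 hydrogen-bond acceptors to 1, yet this assay shows no change at the digits printed from compound 2 to compound 3 (within the scatter). Against the carbamoyl group, the same exchange gives a 1.7-fold lower number from compound 1 to compound 3 (0.23 log units; within the scatter), so all three groups now sit within the scatter of one another, and the earlier pair alone could not show that a group with two aromatic rings also stays within it. No supporting measurement here accounts for why the three groups read alike.

These three compounds do not show how far this insensitivity extends, for example whether a carboxylic acid, a primary amine or a longer alkyl chain on this nitrogen would also stay within the scatter. They also leave open whether a quinolin-2-yl group carrying a further substituent, such as a methoxy group, would give a step large enough to be read beyond the scatter in this assay.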